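Alkene geometry swap in a triazolyl glycoside oxindole series

This account rests on a few compounds, and the source may have more. Where it says the series, first, only, none or still open, it means among the compounds named here.

Compound 1 `CC(=O)OC[C@H]1O[C@@H](n2cc(CN3C(=O)/C(=C/c4ccccc4)c4ccccc43)nn2)[C@H](OC(C)=O)[C@@H](OC(C)=O)[C@@H]1OC(C)=O`: in a functional assay on MCF7 cells (Homo sapiens) for cytotoxicity, read by sulforhodamine B assay, with a stated time of 48 h (on this read-out lower numbers stand for stronger inhibition and higher numbers for weaker inhibition), compound 1 gives 30200 nM.
Compound 2 `CC(=O)OC[C@H]1O[C@@H](n2cc(CN3C(=O)/C(=C/c4ccc(C)cc4)c4ccccc43)nn2)[C@H](OC(C)=O)[C@@H](OC(C)=O)[C@@H]1OC(C)=O`: in this assay compound 2 reaches only the limit of the assay, > 100000 nM.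
Compound 3 `CC(=O)OC[C@H]1O[C@@H](n2cc(CN3C(=O)/C(=C\C=C\c4ccccc4)c4ccccc43)nn2)[C@H](OC(C)=O)[C@@H](OC(C)=O)[C@@H]1OC(C)=O`: in this assay compound 3 gives 34100 nM.

Compound 3 holds the highest of the two values that are actual numbers, yet compound 1 lies so close that the two fall within the scatter of each other and no order can be read between them; the remaining value for compound 2 is a limit, not a number. Within the data shown here, the only measured step, an at least 3.3-fold higher number from compound 1 to compound 2 (0.51 log units; beyond the scatter), concerns a methyl entering on an aromatic carbon, and its size is bounded by the limit (the limit of > 100000 nM in this assay, at which 1 of the 3 values shown sits).

Compound 4 `CC(=O)OC[C@H]1O[C@@H](n2cc(CN3C(=O)/C(=C/C=C/c4ccccc4)c4ccccc43)nn2)[C@H](OC(C)=O)[C@@H](OC(C)=O)[C@@H]1OC(C)=O` differs from compound 3 in that (the two compounds have the same atoms and bonds and differ only in configuration as drawn: 1 of 7 stereo elements differ; a double bond is drawn Z in compound 3 and E in compound 4). Among the measured compounds shown here, no measured step concerns a change of configuration alone, and the step from compound 1 to compound 2 involves a change of atoms, so it does not bear on this one. With nothing to suggest otherwise, compound 4 is expected to land close to compound 3, with a 1.0-fold lower number from compound 3 to compound 4 (0.00 log units; within the scatter) within the scatter. Compound 4 is estimated at 34000 nM, within 12000 nM to 100000 nM.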

Compound 4, half-maximal inhibitory concentration: 53200 nM
Compound 4: middle estimate off by 1.6-fold (0.19 log units), on the low side, within the range that was stated.
By their numbers in this assay, from the lowest: compounds 1, 3 and 4 (each within the scatter of the next). At a limit, above all of these: compound 2.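

Among these compounds, until now no step had concerned configuration alone. In this assay, a double bond drawn Z in one compound and E in the other gives a 1.6-fold higher number from compound 3 to compound 4 (0.19 log units; within the scatter), so no order can be read between the two forms: the fact that compounds 3 and 4 differ only in the configuration as drawn
With 2-phenylethenyl in place of phenyl on the double-bonded chain carbon, the result is a 1.8-fold higher number from compound 1 to compound 4 (0.25 log units; within the scatter), so this exchange also brings no readable change in the number. With 2-phenylethenyl in place of 4-methylphenyl, the result is an at least 1.8-fold lower number from compound 2 to compound 4 (0.27 log units; that floor lies within the scatter), and this is only a floor, set by the value of compound 2, which is a limit and not a number: the limit of > 100000 nM in this assay, at which 1 of the 4 values shown sits.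

Going by these compounds, it remains open whether an amine or a carboxylic acid on the terminal phenyl would move the number beyond the scatter, as the methyl of compound 2 did. On these data alone, it is also open whether free hydroxyl groups in place of the acetyl groups on the shared core would change the number, and whether the double bond's configuration would matter in such compounds.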